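The source may hold more compounds than are shown below. What is called first, only, known or untested is meant among the compounds shown, and "the series" means these compounds.

Of the compounds shown here, three share one core and have been tested in a functional assay (aorta) with Rattus norvegicus as the target; a higher number here means a more potent compound, by a factor of ten per unit of this negative logarithm, a lower number a less potent compound. Compound 1 `CC1(C)C=C(n2ccccc2=O)c2cc(C=O)ccc2O1` gives 6.91, compound 2 `Cc1ccc(C)n1-c1ccc2c(c1)C(n1ccccc1=O)=CC(C)(C)O2` gives 7.27, and compound 3 `CC(=O)Oc1ccc2c(c1)C(n1ccccc1=O)=CC(C)(C)O2` gives 5.6. Compound 3 thus stands lowest of the three, nearest to compound 1 and furthest from compound 2. The two steps that end at compound 3 were both large: a number 1.31 log units lower from compound 1 to compound 3 (beyond the scatter) and a number 1.67 log units lower from compound 2 to compound 3 (beyond the scatter). In each of them the acetoxy group entered and the number fell well beyond the scatter, so the acetoxy group goes with the weakest reading seen here.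

Compound 4 `CC1(C)C=C(n2ccccc2=O)c2cc(C(F)(F)F)ccc2O1` is not yet measured. It differs from compound 3 in one place: trifluoromethyl in place of acetoxy on an aromatic carbon. Since both measured steps that bear on this position show a large loss when acetoxy arrives, its removal in favour of trifluoromethyl is expected to recover much of that loss, with a step of roughly a number 1.30 log units higher from compound 3 to compound 4 (beyond the scatter) in this assay. Compound 4 is therefore estimated at 6.9, most likely between 6 and 7.6.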

Compound 4, logarithm of the reciprocal of the active concentration, log(1/C): 7.61
For compound 4 the middle estimate is 0.71 log units below the measured one; measured number outside the range, above it.
By their numbers in this assay, from the lowest: compound 3; then compound 1; then compound 2; then compound 4.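

Acetoxy and trifluoromethyl have the same count of heavy atoms on this aromatic carbon, yet in this assay the exchange gives a number 2.01 log units higher from compound 3 to compound 4 (beyond the scatter) and so that count alone does not set the reading here. Trifluoromethyl, which has no hydrogen-bond acceptors, also outdoes both other groups, with a number 0.34 log units higher from compound 2 to compound 4 (beyond the scatter) and with a number 0.70 log units higher from compound 1 to compound 4 (beyond the scatter) as well, making compound 4 the most potent of the four and showing that a high reading needs no acceptor in this group. Nothing measured here explains these differences.

The compounds shown leave open how an amine, a carboxylic acid or a nitrile on this carbon would read. As far as these compounds go, they also change only this one place, so whether trifluoromethyl keeps its lead with a different group elsewhere on the shared core remains unknown.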